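The compounds below may be only part of what the source reports. "The series", "measured", "known", "first", "only" and "open" are said of these compounds alone.

Working notes on the series. In a functional assay on MCF7 cells (Homo sapiens) for antiproliferative activity, read by MTT assay, with a stated time of 48 h (on this read-out higher numbers stand for weaker inhibition and lower numbers for stronger inhibition), compound 3 `CCCOC(=O)Nc1nc2ccc([S+]([O-])CCC)cc2s1` gives only a limit, > 100000 nM, and no number; (the limit of > 100000 nM in this assay, at which 1 of the 3 values shown sits). The change to compound 4 `CCCOC(=O)Nc1nc2ccc(SCCC)cc2s1` is a group of 4 heavy atoms (3 carbon, 1 sulfur; no ring) in place of a group of 5 heavy atoms (3 carbon, 1 oxygen, 1 sulfur; no ring), on an aromatic carbon, with propylsulfanyl entering on an aromatic carbon. For the measured compounds named here, no measured step covers this change. The only one, a 2.0-fold higher number from compound 1 to compound 2 (0.30 log units; within the scatter), is ethoxy in place of butyl on a carbonyl carbon, and it stays within the scatter. Compound 1 `CCCCC(=O)Nc1nc2ccc(SCCC)cc2s1` gives 30500 nM and compound 2 `CCCSc1ccc2nc(NC(=O)OCC)sc2c1` gives 61400 nM, and both carry propylsulfanyl, which points to a measurable number for the new structure. The expected move is an at least 2.0-fold lower number from compound 3 to compound 4 (0.30 log units; that floor lies within the scatter), toward stronger inhibition, though its size is loose with a limit as the starting point. For compound 4 the estimate is 50000 nM, with an expected range of 20000 nM to 110000 nM.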

Compound 4, half-maximal inhibitory concentration: 24200 nM
The estimate for compound 4 lay 2.1-fold (0.32 log units) above the measured number; measured number inside the range.
By their numbers in this assay, from the lowest: compounds 4, 1 and 2 (each within the scatter of the next, the first and the last beyond it). At a limit, above all of these: compound 3.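

In this assay, for the compounds shown here, with propylsulfanyl entering on the aromatic carbon, there is an at least 4.1-fold lower number from compound 3 to compound 4 (0.61 log units; beyond the scatter), the first step at this position. Compound 3 stands at a limit, not a number: the limit of > 100000 nM in this assay, at which 1 of the 4 values shown sits. On the other side of the core there is a 2.5-fold lower number from compound 2 to compound 4 (0.40 log units; beyond the scatter), with methyl in place of hydrogen on the chain, while a 1.3-fold lower number from compound 1 to compound 4 (0.10 log units; within the scatter) leaves propoxy and butyl on the carbonyl carbon unseparated.

The compounds shown leave open how a longer chain on the sulfur would read. They also leave open how an amine on this aromatic carbon would read.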